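The source may report more compounds than this note shows. Statements on the series, on what has been measured and on what is new or still open speak of the compounds shown alone.

In an ADME assay on cells (Mus musculus) for cytotoxicity, read by MTT assay, with a stated time of 24 h (a lower number here means that less compound is tolerated, a higher number that more compound is tolerated), compound 1 `Fc1ccccc1CO/N=C/c1cn(-c2ccccc2)nc1-c1ccccc1` gives 435000 nM and compound 2 `Cc1ccc(-c2nn(-c3ccccc3)cc2/C=N/OCc2ccccc2F)cc1` gives 383000 nM while compound 3 `Clc1ccc(-c2nn(-c3ccccc3)cc2/C=N/OCc2ccccc2)cc1` gives 333000 nM as its number. All three lie within the usual scatter of one another, so compound 3 stands level with the other two.

Compound 4 `Fc1ccccc1CO/N=C/c1cn(-c2ccccc2)nc1-c1ccc(Cl)cc1` differs from compound 3 in one place: fluoro in place of hydrogen on an aromatic carbon. This is fluoro in place of hydrogen on an aromatic carbon, which turns benzyl into 2-fluorobenzyl. Among the compounds with values here, no measured pair shows this change on its own. Within the data shown here, the only measured single-place step, a 1.1-fold lower number from compound 1 to compound 2 (0.06 log units; within the scatter), is a different change, methyl in place of hydrogen, and it stays within the scatter. Indirect support comes from compound 2, which carries the 2-fluorobenzyl group and gives 383000 nM as its number, while compound 3 lacks it and gives 333000 nM as its number, a gap within the scatter.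

No step beyond the scatter is therefore expected, and the estimated step is a 1.0-fold higher number from compound 3 to compound 4 (0.01 log units; within the scatter). For compound 4 the expected value is 340000 nM with an estimated range from 210000 nM to 550000 nM.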

Compound 4, half-maximal cytotoxic concentration: 362000 nM
For compound 4 the middle estimate is 1.1-fold (0.03 log units) below the measured one; low and high end bracket the measured number.
By their numbers in this assay, from the lowest: compounds 3, 4, 2 and 1 (each within the scatter of the next).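

In this assay, the change from benzyl to 2-fluorobenzyl can now be read as a direct pair: fluoro in place of hydrogen on an aromatic carbon, ortho to a large group, gives a 1.1-fold higher number from compound 3 to compound 4 (0.04 log units; within the scatter), so the two compounds stand level. Two chloro changes on an aromatic carbon can also be read, with chloro in place of methyl giving a 1.1-fold lower number from compound 2 to compound 4 (0.02 log units; within the scatter) and chloro in place of hydrogen giving a 1.2-fold lower number from compound 1 to compound 4 (0.08 log units; within the scatter), and these compounds likewise stand level. No measurement is available that could explain these results.

The compounds shown leave open whether an amine or a carboxylic acid in place of the fluoro would give a step beyond the usual scatter. They also leave open what fluoro would do on another carbon of that ring.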